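The compounds below may be only part of what the source reports. "The series", "measured", "known", "first", "only" and "open" are said of these compounds alone.

Measured compounds:
Compound 1 `CCCC(=O)n1nc(C)c(-c2ccc(Cl)c(Cl)c2)c1N`: in an assay on Sf9 cells for inhibition of mitogen-activated protein kinase kinase kinase 14 (Homo sapiens), read by ADP-Glo, with a stated time of 60 min (on this read-out higher numbers stand for weaker inhibition and lower numbers for stronger inhibition), compound 1 gives > 100000 nM, which is a limit of the assay and not a number.
Compound 2 `Cc1nn(C(=O)C2CCC2)c(N)c1-c1ccc(Cl)c(Cl)c1`: in this assay compound 2 gives 2900 nM.
Compound 3 `Cc1nn(C(=O)c2ccccc2)c(N)c1-c1ccc(Cl)c(Cl)c1`: in this assay compound 3 gives 23000 nM.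

Compound 3 stands highest of the two numbers shown; its nearest neighbour is compound 2, with a 7.9-fold higher number from compound 2 to compound 3 (0.90 log units; beyond the scatter). Compound 1 sits at a limit (the limit of > 100000 nM in this assay, at which 1 of the 3 values shown sits) and gives no number to place.

Compound 4 `CCNC(=O)n1nc(C)c(-c2ccc(Cl)c(Cl)c2)c1N` differs from compound 3 by ethylamino in place of phenyl on a carbonyl carbon. All three measured steps change the group on this carbonyl carbon: an at least 34-fold lower number from compound 1 to compound 2 (1.53 log units; beyond the scatter), an at least 4.3-fold lower number from compound 1 to compound 3 (0.63 log units; beyond the scatter) and a 7.9-fold higher number from compound 2 to compound 3 (0.90 log units; beyond the scatter). The ring groups of compound 2 and compound 3 gave the numbers; the open-chain propyl of compound 1 gave only a limit. Ethylamino is again an open chain without a ring, so a higher number than compound 3 is expected in this assay, of modest size, with a real chance that only a limit is returned.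

Compound 4 is expected to give 50000 nM, between 8000 nM and 100000 nM, which is an estimated 2.2-fold higher number from compound 3 to compound 4 (0.34 log units; beyond the scatter).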

Compound 4, half-maximal inhibitory concentration: > 100000 nM
Compound 4: only a limit was reported (the forecaster's own chance of this, stated with the estimate: 35%); at least 2.0-fold (0.30 log units) between middle value and limit.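

In this assay, ethylamino on the carbonyl carbon gives an at least 4.3-fold higher number from compound 3 to compound 4 (0.63 log units; beyond the scatter), and the same group in place of cyclobutyl gives an at least 34-fold higher number from compound 2 to compound 4 (1.53 log units; beyond the scatter). Replacing a ring with ethylamino, which brings a nitrogen and a hydrogen-bond donor to this place, therefore does not restore a readable number. Among the four compounds, only cyclobutyl and phenyl give numbers, while the open-chain propyl of compound 1 and ethylamino of compound 4 both end at a limit, so the step between those two cannot be read: the limit of > 100000 nM in this assay, at which 2 of the 4 values shown sit.

The compounds shown do not separate the loss of a ring from the arrival of the nitrogen; phenylamino or cyclobutylamino on this carbonyl carbon would bear on that. On these data alone, whether a branched chain such as isopropyl, or a smaller ring such as cyclopropyl, gives a number also stays open.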